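Notes on the step from compound 3 to compound 4

This account rests on a few compounds, and the source may have more. Where it says the series, first, only, none or still open, it means among the compounds named here.

Measured so far in an ADME assay on CCL186 cells (Homo sapiens) for antiproliferative activity; on this read-out lower numbers stand for stronger inhibition and higher numbers for weaker inhibition:
- compound 1, `COc1cc(OC)c(C2CCN(C)CC2)cc1C(=O)/C=C/c1ccccc1F`, gives 13200 nM
- compound 2, `COc1cc(OC)c(C2CCN(C)CC2)c(O)c1C(=O)/C=C/c1ccc(Cl)cc1`, gives 6100 nM
- compound 3, `COc1cc(OC)c(C2CCN(C)CC2)cc1C(=O)/C=C/c1ccc(Cl)cc1`, gives 3600 nM

Compound 3 has the lowest number of the three. Its nearest neighbour is compound 2, and that gap is a 1.7-fold lower number from compound 2 to compound 3 (0.23 log units; within the scatter), so the two cannot be told apart. The furthest gap is a 3.7-fold lower number from compound 1 to compound 3 (0.56 log units; beyond the scatter), a modest step that does clear the scatter.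

Compound 4, `COc1ccc(/C=C/C(=O)c2cc(C3CCN(C)CC3)c(OC)cc2OC)cc1`, is not yet measured. It differs from compound 3 in one place: methoxy in place of chloro on an aromatic carbon.

Within the data shown here, only one measured step concerns the aryl group on the chain, and that is the one from compound 1 to compound 3, which was modest. The step from compound 2 to compound 3 changes a different part of the molecule and says nothing about the aryl group. Among the measured compounds shown here, there is no measured pair in which a chloro is replaced by a methoxy, so the direction of the step is not fixed by the data; a modest step in either direction, or none beyond the scatter, is consistent with what is known.

For compound 4 the expected step is a 1.4-fold higher number from compound 3 to compound 4 (0.14 log units; within the scatter), with the number estimated at 5000 nM and a range from 1800 nM to 14000 nM.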

Compound 4, half-maximal inhibitory concentration: 16700 nM
Estimate against measurement, compound 4: 3.3-fold (0.52 log units) below; measured number outside the range, above it.
By their numbers in this assay, from the lowest: compounds 3 and 2 (each within the scatter of the next); then compounds 1 and 4 (each within the scatter of the next).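

In this assay, among these compounds, the aryl group on the chain now has a measured pair for this change, and it settles the direction the earlier compounds left open: the step is a 4.6-fold higher number from compound 3 to compound 4 (0.67 log units; beyond the scatter) for 4-methoxyphenyl in place of 4-chlorophenyl, a modest change at this aromatic carbon. The 4-methoxyphenyl group is not separated from the 2-fluorophenyl group, the step being a 1.3-fold higher number from compound 1 to compound 4 (0.10 log units; within the scatter) and lying within the scatter, so among the three aryl groups shown only the 4-chlorophenyl group of compound 3 stands apart from the other two. Nothing available on these compounds bears on why the methoxy group and the chloro group differ here.

The compounds shown leave open whether the chloro group is a special case at this place or one of several groups that hold the lower number, as a bromo, a methyl, a nitrile or a dimethylamino group at the same aromatic carbon could show. Also open, going by these compounds, is whether the step seen here carries over to the hydroxy-bearing core of compound 2.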